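Tetrahydroisoquinoline in place of benzyloxy: expected solubility

A few compounds are considered here, and "the series" means these few. Any claim that something is new, unique, unknown or untested is made for them only; others in the source may bear on it.

Measured compounds:
compound 1 `COc1ccc2[nH]c(C(=O)N3CC(=O)N(Cc4ccccc4)[C@@H](COCc4ccccc4)C3)cc2c1` — 8800 nM
compound 2 `COc1ccc2[nH]c(C(=O)N3CC(=O)N(Cc4cccc(OC)n4)[C@@H](Cc4ccccc4)C3)cc2c1` — 47500 nM
compound 3 `COc1cccc(CN2C(=O)CN(C(=O)c3cc4cc(OC)ccc4[nH]3)C[C@@H]2c2ccccc2)c1` — 13600 nM

In a physicochemical assay for solubility, read by spectrophotometry, in phosphate buffer, with a stated time of 2 h, at pH 7.4 (on this read-out higher numbers stand for higher solubility and lower numbers for lower solubility), compound 1 gives 8800 nM, the lowest of the three numbers. Compound 3 gives 13600 nM, which lies within the scatter of the number for compound 1, so the two cannot be told apart. Compound 2 gives 47500 nM, a gap beyond the scatter, so compound 2 is the only one clearly more soluble than compound 1.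

Compound 4 `COc1ccc2[nH]c(C(=O)N3CC(=O)N(Cc4ccccc4)[C@@H](CN4CCc5ccccc5C4)C3)cc2c1` has not yet been measured. It differs from compound 1 in one place: 1,2,3,4-tetrahydroisoquinolin-2-yl in place of benzyloxy on a saturated chain carbon bound to a saturated ring carbon. Going by the values given here, no pair among the measured compounds shows this change, so the step cannot be read from a measured step.

The step from compound 1 to compound 4 is expected to be modest and upward, a 2.3-fold higher number from compound 1 to compound 4 (0.36 log units; beyond the scatter), though a result within the scatter would not be surprising. Compound 4 is therefore estimated at 20000 nM in this assay, with a range from 6000 nM to 65000 nM.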

Compound 4, solubility: 9000 nM
Estimate against measurement, compound 4: 2.2-fold (0.35 log units) above; low and high end bracket the measured number.
By their numbers in this assay, from the lowest: compounds 1, 4 and 3 (each within the scatter of the next); then compound 2.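

In this assay, going by these compounds alone, the exchange of benzyloxy for 1,2,3,4-tetrahydroisoquinolin-2-yl on a saturated chain carbon bound to a saturated ring carbon gives the first step that can be read at this position: a 1.0-fold higher number from compound 1 to compound 4 (0.01 log units; within the scatter). In this read-out the two groups cannot be told apart here, even though the entering group carries a nitrogen where the leaving group carries an oxygen and adds a non-aromatic ring, with the same count of hydrogen-bond acceptors. No measurement at hand explains why these two numbers lie within the scatter of each other.

On these data alone, whether a morpholine ring, a dimethylamino group or a carboxylic acid on the same chain carbon would read differently remains open. Also open, as far as these compounds go, is whether the same exchange would give a similar step on any compound other than compound 1.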